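A few compounds are considered here, and "the series" means these few. Any claim that something is new, unique, unknown or untested is made for them only; others in the source may bear on it.

Measured so far: compound 1 `COc1cc(/C=C/C(=O)C2=C(/C=C/c3ccc(O)c(OC)c3)NC(=O)NC2c2ccccc2)ccc1O` with 10.5%; compound 2 `COc1cc(/C=C/C(=O)C2=C(/C=C/c3ccc(O)c(OC)c3)NC(=O)NC2c2c(Cl)cccc2Cl)ccc1O` with 11.2%.

Both numbers come from a functional assay, with a stated time of 20 min, tested at 2 uM; on this read-out higher numbers stand for a stronger effect at the one concentration tested and lower numbers for a weaker effect. Among the compounds with values here, compound 2 sits alongside compound 1 on this read-out: the only step recorded, a number 0.7 percentage points higher from compound 1 to compound 2 (within the scatter), is too small to tell the two apart, so neither can be called stronger or weaker. That step swapped phenyl for 2,6-dichlorophenyl on a saturated ring carbon of the shared core and left the activity essentially unchanged.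

Compound 3 `COc1cc(/C=C/C(=O)C2=C(/C=C/c3ccc(O)c(OC)c3)NC(=O)NC2c2cccc([N+](=O)[O-])c2)ccc1O` differs from compound 2 in one place: 3-nitrophenyl in place of 2,6-dichlorophenyl on a saturated ring carbon. This is the same position of the core that the measured step altered. That step, a number 0.7 percentage points higher from compound 1 to compound 2 (within the scatter), is the only one that bears on the present change, and it was within the scatter. Within the data shown here, there is no measured step involving a nitro group, so nothing in the numbers points to a shift in either direction. In this assay compound 3 is therefore expected to give a value close to that of compound 2, with the estimated step of a number 0.2 percentage points lower from compound 2 to compound 3 (within the scatter) not beyond the scatter. The estimate for compound 3 is 11%, with a range from 3% to 22%.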

Compound 3, a percentage reported as activity, at one concentration (the size of the read-out at that concentration, not a potency): 10.2%
The estimate for compound 3 lay 0.8 percentage points above the measured number; low and high end bracket the measured number.
By their numbers in this assay, from the lowest: compounds 3, 1 and 2 (each within the scatter of the next).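

In this assay, the change from the chlorinated ring to the nitro-bearing ring gives a number 1 percentage points lower from compound 2 to compound 3 (within the scatter) and so does not separate these two groups, and adding nitro in place of hydrogen on an aromatic carbon of the plain phenyl gives a number 0.3 percentage points lower from compound 1 to compound 3 (within the scatter) and does not separate those two either. The earlier pair showed this only for 2,6-dichlorophenyl against phenyl, whereas phenyl, 2,6-dichlorophenyl and 3-nitrophenyl on this saturated ring carbon now cannot be told apart on this read-out, even though the 3-nitrophenyl group brings hydrogen-bond acceptors and the 2,6-dichlorophenyl group has none. Nothing measured offers a reason for this flat result.

From the compounds shown here alone, all three groups at this place are six-membered aromatic rings of carbon only, so it remains open whether a saturated cyclohexyl ring, a short alkyl chain or a phenyl ring carrying an amine or a carboxylic acid would give a number beyond the scatter. The comparison also rests on one concentration, so it leaves open whether these compounds would still match at other concentrations.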